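The source may report more compounds than this note shows. Statements on the series, on what has been measured and on what is new or still open speak of the compounds shown alone.

Working notes on the series. Compound 1 `O=C(Nc1ccc(Oc2ccnc3[nH]ccc23)cc1)c1cc2cccnc2n(-c2ccc(F)cc2)c1=O` gives 160 nM in a functional assay on HT-29 cells (Homo sapiens) for antiproliferative activity, read by MTT assay, with a stated time of 72 h; a higher number here means a weaker inhibitor, a lower number a stronger inhibitor. Compound 3 `Cn1ccc2c(Oc3ccc(NC(=O)c4cc5cccnc5n(-c5ccc(F)cc5)c4=O)cc3)ccnc21` gives 250 nM in this assay; the single-place step a 1.6-fold higher number from compound 1 to compound 3 (0.19 log units; within the scatter) is the only one of its kind in the set. Compound 2 `O=C(Nc1ccc(Oc2ccnc3[nH]ccc23)c(F)c1)c1cc2cccnc2n(-c2ccc(Br)cc2F)c1=O` differs from compound 1 in two places; compound 2 gives 820 nM; on the numbers shown compound 3 sits within the scatter of compound 1 and beyond it from compound 2, compound 2 showing the higher number.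

Compound 4 `Cn1ccc2c(Oc3ccc(NC(=O)c4cc5cccnc5n(-c5ccc(C(F)(F)F)cc5Cl)c4=O)cc3)ccnc21` is not yet measured. The change from compound 3 is 2-chloro-4-(trifluoromethyl)phenyl in place of 4-fluorophenyl on an aromatic nitrogen. Among the compounds with values here, no measured step changes the aryl group on an aromatic nitrogen alone; the one single-place step, a 1.6-fold higher number from compound 1 to compound 3 (0.19 log units; within the scatter), touches another site and is within the scatter. Compound 2, which carries a different aryl group there among its two changes, shows a higher number than compound 1, and that is the only hint available. The step from compound 3 to compound 4 is therefore expected to be a 2.8-fold higher number from compound 3 to compound 4 (0.45 log units; beyond the scatter), toward a higher number, with wide uncertainty. Compound 4 is expected to give 700 nM, within a range of 250 nM to 2000 nM.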

Compound 4, half-maximal inhibitory concentration: 6050 nM
For compound 4 the middle estimate is 8.6-fold (0.94 log units) below the measured one; measured number above the stated range.
By their numbers in this assay, from the lowest: compounds 1 and 3 (each within the scatter of the next); then compound 2; then compound 4.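

In this assay the aryl group on the aromatic nitrogen emerges as a place where a single change has a large effect: 2-chloro-4-(trifluoromethyl)phenyl in place of 4-fluorophenyl gives a 24-fold higher number from compound 3 to compound 4 (1.38 log units; beyond the scatter) with the rest of the molecule unchanged. Within the data shown here, the earlier compounds could not show this, as their only single-place step touched another site and stayed within the scatter, while compound 2 carried a different aryl group alongside a second change. Nothing available here bears on what lies behind the size of this step.

Going by these compounds, the chlorine and the trifluoromethyl enter together, so the share of each in the step remains open. Also open, on these data alone, is how an aryl group carrying an amine or a carboxylic acid at this place would read in this assay.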